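Trading a bromobutoxy chain for a dihydroxypropoxy chain

The source may hold more compounds than are shown below. What is called first, only, known or untested is meant among the compounds shown, and "the series" means these compounds.

Compound 3 `O=c1c(-c2ccc(O)cc2)coc2cc(OCCCCBr)ccc12` stands second highest of the three compounds measured. In a functional assay on mitochondria (Cricetulus griseus) for inhibition of Monoamine oxidase (Homo sapiens), tested at 0.9 uM (a lower number here means a weaker effect, a higher number a stronger effect of the compound at the concentration tested), compound 3 gives 55.3%, while compound 1 `CCOc1ccc2c(=O)c(-c3ccc(O)cc3)coc2c1` gives 86.9% and compound 2 `O=c1c(-c2ccc(O)cc2)coc2cc(CC3OC(CO)C(O)C(O)C3O)ccc12` gives 0%. Compound 4 `O=c1c(-c2ccc(O)cc2)coc2cc(OCC(O)CO)ccc12` is not yet measured; it differs from compound 3 in one place: 1,2-dihydroxyethyl in place of 3-bromopropyl on a saturated chain carbon bound to an oxygen on an aromatic ring.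

Going by the values given here, only one measured step concerns this part of the structure, the one from compound 1 to compound 3, where a number 31.6 percentage points lower from compound 1 to compound 3 (beyond the scatter). Lengthening the chain on the aromatic oxygen therefore already cost inhibition. Compound 2, which carries a hydroxyl-rich ring on the core in place of that chain, gives the lowest number. Among the compounds with values here, no measured pair shows the exact swap of a bromine-bearing chain for a hydroxyl-bearing one, so the expectation is uncertain, but both of these observations point downward. The author expects compound 4 to show a further drop in this assay, with a number 25.3 percentage points lower from compound 3 to compound 4 (beyond the scatter), and estimates for compound 4 a value of 30%, within a range from 5% to 60%.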

Compound 4, a percentage reported as inhibition, at one concentration (the size of the read-out at that concentration, not a potency): 63.8%
For compound 4 the middle estimate is 33.8 percentage points below the measured one, and the stated range ends below it.
By their numbers in this assay, from the lowest: compound 2; then compounds 3 and 4 (each within the scatter of the next); then compound 1.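

In this assay, the change from 4-bromobutoxy to 2,3-dihydroxypropoxy gives a number 8.5 percentage points higher from compound 3 to compound 4 (within the scatter), so at this position the two chains cannot be told apart, although the entering group brings hydroxyl groups and the leaving group a bromine. The step from the shorter chain shows a number 23.1 percentage points lower from compound 1 to compound 4 (beyond the scatter), so compound 3 and compound 4 both fall short of compound 1, whichever of the two end groups the longer chain carries. No measured evidence bears on why these numbers fall as they do.

The compounds shown do not separate the effect of chain length from that of the chain's end group. On these data alone, how a chain ending in an amine or a carboxylic acid would read at this position also remains open.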